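A few compounds are considered here, and "the series" means these few. Any claim that something is new, unique, unknown or untested is made for them only; others in the source may bear on it.

Compound 1 `CC(C)Cn1c(=O)n(C)c(=O)c2c1nc(Cc1cccc3ccccc13)c(=O)n2CCCCCCO`, compound 2 `CC(C)Cn1c(=O)n(C)c(=O)c2nc(SCCO)c(Cc3cccc4ccccc34)nc21` and compound 3 `CC(C)Cn1c(=O)n(C)c(=O)c2nc(S(=O)(=O)CCCO)c(Cc3cccc4ccccc34)nc21` share a core carrying a (naphthalen-1-yl)methyl group and were compared in a functional assay on Raji cells (Homo sapiens) for inhibition, read by MTT assay, with a stated time of 96 h; a lower number here means that less compound is needed, a higher number that more compound is needed for the effect. For compound 1 the result is > 10000 nM, a limit of the assay, namely (the limit of > 10000 nM in this assay, at which 1 of the 3 values shown sits). Compound 2 gives 2850 nM, and compound 3 gives 3750 nM, so compound 3 holds the highest of the two numbers, with compound 2 its nearest neighbour. For the measured compounds named here, the single measured step, a 1.3-fold higher number from compound 2 to compound 3 (0.12 log units; within the scatter), is the only step that bears on the change now considered. Compound 4 `CC(C)Cn1c(=O)n(C)c(=O)c2nc(-c3c(CCCO)nnn3C)c(Cc3cccc4ccccc34)nc21` differs from compound 3 in that (4-(3-hydroxypropyl)-1-methyl-1H-1,2,3-triazol-5-yl in place of (3-hydroxypropyl)sulfonyl on an aromatic carbon). Going by the values given here, the measured step kept a hydroxyalkyl chain and changed only the sulfur-containing link, and it stayed within the scatter; the present change replaces the sulfonyl group with an aromatic ring, a kind of change no measured step covers. The estimate therefore means a 1.2-fold higher number from compound 3 to compound 4 (0.08 log units; within the scatter), a step expected not to exceed the scatter, though with a wide range. Compound 4 is estimated at 4500 nM, between 1500 nM and 12000 nM.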

Compound 4, half-maximal effective concentration: > 10000 nM
Compound 4 was reported as a limit; the forecaster's own chance of this, stated with the estimate: 25%; at least 2.2-fold (0.34 log units) between middle value and limit.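

At this position, on an aromatic carbon ortho to a (naphthalen-1-yl)methyl group, the link carrying the hydroxyalkyl chain now matters in this assay: exchanging one sulfur link for the other gave only a 1.3-fold higher number from compound 2 to compound 3 (0.12 log units; within the scatter), whereas the 4-(3-hydroxypropyl)-1-methyl-1H-1,2,3-triazol-5-yl group in place of (3-hydroxypropyl)sulfonyl gives an at least 2.6-fold higher number from compound 3 to compound 4 (0.42 log units; beyond the scatter). Set against (2-hydroxyethyl)sulfanyl, the same group gives an at least 3.5-fold higher number from compound 2 to compound 4 (0.54 log units; beyond the scatter), so both sulfur-linked compounds stand apart from this triazole. The value of compound 4 is a limit and not a number, the second such limit in the series: the limit of > 10000 nM in this assay, at which 2 of the 4 values shown sit.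

As far as these compounds go, how large the loss really is stays open, since a limit bounds the step only from one side. Also open, from the compounds shown here alone, is whether an amine or a carboxylic acid at the chain end, or a phenyl ring in place of the triazole, would behave like the sulfur links.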